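This account rests on a few compounds, and the source may have more. Where it says the series, first, only, none or still open, it means among the compounds named here.

In a functional assay on A549 cells (Homo sapiens) for cytotoxicity, read by MTT assay, with a stated time of 72 h (a lower number here means a stronger inhibitor, a higher number a weaker inhibitor), compound 1 `CN1CCN(CCCCn2c3c(c4ccccc42)C(=O)c2c[n+]([O-])c4ccccc4c2C3=O)CC1` gives 90 nM, compound 2 `O=C1c2c[n+]([O-])c3ccccc3c2C(=O)c2c1c1ccccc1n2CCCCN1CCNCC1` gives 540 nM and compound 3 `O=C1c2c[n+]([O-])c3ccccc3c2C(=O)c2c1c1ccccc1n2CCN1CCCCC1` gives 1080 nM. Compound 3 stands close to compound 2, a 2.0-fold higher number from compound 2 to compound 3 (0.30 log units; within the scatter), and far from compound 1, a 12-fold higher number from compound 1 to compound 3 (1.08 log units; beyond the scatter).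

The next change leads to compound 4 `O=C1c2c[n+]([O-])c3ccccc3c2C(=O)c2[nH]c3ccccc3c21`: hydrogen in place of 2-(piperidin-1-yl)ethyl on an aromatic nitrogen. Within the data shown here, no measured step removes the group on this nitrogen outright, so the evidence is indirect. Changes within that group range from a step inside the scatter, a 2.0-fold higher number from compound 2 to compound 3 (0.30 log units; within the scatter), through a 6.0-fold higher number from compound 1 to compound 2 (0.78 log units; beyond the scatter), to the large 12-fold higher number from compound 1 to compound 3 (1.08 log units; beyond the scatter). Removing the whole group is a larger structural change than any of these, and the direction is uncertain. A modest move to a higher number in this assay is the working expectation, though a step within the scatter cannot be excluded. The expected step is a 2.3-fold higher number from compound 3 to compound 4 (0.36 log units; beyond the scatter). The estimate for compound 4 is 2500 nM, with an expected range of 600 nM to 10000 nM.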

Compound 4, half-maximal inhibitory concentration: 320 nM
Compound 4: the middle estimate sits 7.8-fold (0.89 log units) above what was measured, outside the stated range (below it).
By their numbers in this assay, from the lowest: compound 1; then compounds 4, 2 and 3 (each within the scatter of the next, the first and the last beyond it).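

On the aromatic nitrogen, hydrogen in place of 2-(piperidin-1-yl)ethyl gives a lower number in this assay (a 3.4-fold lower number from compound 3 to compound 4 (0.53 log units; beyond the scatter)), so the core of compound 4 needs no group at this position for cytotoxicity, and this group compares unfavourably with hydrogen. The outcome depends on the group: replacing 4-(piperazin-1-yl)butyl with hydrogen stays within the scatter (a 1.7-fold lower number from compound 2 to compound 4 (0.23 log units; within the scatter)), whereas replacing 4-(4-methylpiperazin-1-yl)butyl with hydrogen raises the number (a 3.6-fold higher number from compound 1 to compound 4 (0.55 log units; beyond the scatter)), leaving that group alone ahead of hydrogen. No measurement is available that explains these differences.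

Chain length and terminal ring remain entangled in this set, and a 4-(piperidin-1-yl)butyl or 2-(4-methylpiperazin-1-yl)ethyl group would separate them. On these data alone, how a simple methyl on this nitrogen compares with hydrogen also remains open.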